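Swapping trifluoromethyl for fluoro on a second core

A few compounds are considered here, and "the series" means these few. Any claim that something is new, unique, unknown or untested is made for them only; others in the source may bear on it.

Measured so far:
compound 1 `Fc1ccc(N2N=NCC2c2ccncc2)cc1` — 203 mg/kg
compound 2 `FC(F)(F)c1ccc(N2N=NCC2c2ccncc2)cc1` — 421 mg/kg
compound 3 `FC(F)(F)c1ccc(-n2nncc2-c2cccnc2)cc1` — 90.5 mg/kg

These values come from a functional assay on the whole organism with Mus musculus as the target; a lower number here means that less compound is needed, a higher number that more compound is needed for the effect. Compound 3 has the lowest number of the three. Compound 2 and compound 1 share a core and differ by fluoro in place of trifluoromethyl on an aromatic carbon, which gave a 2.1-fold lower number from compound 2 to compound 1 (0.32 log units; beyond the scatter). Compound 3 carries a different core; how its core differs from that of compound 2 is not broken down here.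

Compound 4 `Fc1ccc(-n2nncc2-c2cccnc2)cc1` is not yet measured. It differs from compound 3 by fluoro in place of trifluoromethyl on an aromatic carbon, the same kind of change as from compound 2 to compound 1, at a place described in the same words. Because a 2.1-fold lower number from compound 2 to compound 1 (0.32 log units; beyond the scatter) lowered the number, a step of similar size is expected on the new core, giving a 1.9-fold lower number from compound 3 to compound 4 (0.28 log units; within the scatter) in this assay. Compound 4 is therefore estimated at 48 mg/kg, likely between 20 mg/kg and 120 mg/kg.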

Compound 4, dose for half-maximal effect: 47.9 mg/kg
Beside the measured number, compound 4's estimate is 1.0-fold (0.00 log units) above it, and the stated range covers the measured number.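

In this assay, fluoro in place of trifluoromethyl gives a 1.9-fold lower number from compound 3 to compound 4 (0.28 log units; within the scatter). Set beside the same change on the other core, the two steps agree: the same change on two cores in this assay, a 2.1-fold lower number (0.32 log units; beyond the scatter) from compound 2 to compound 1 and a 1.9-fold lower number (0.28 log units; within the scatter) from compound 3 to compound 4, 1.1-fold (0.04 log units) apart, within the scatter of two such steps This shows that, across these two pairs, the change carried over from one core to the other at a similar size, but the new step alone lies within the scatter, and two pairs cannot show that it would hold on other cores or explain why the steps match.

The compounds shown carry only fluoro or trifluoromethyl at this place on the ring. As far as these compounds go, how a chloro group, a methoxy group or an amine there would compare on either core remains open.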